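The compounds below may be only part of what the source reports. "The series", "measured", "known", "first", "only" and "open" are said of these compounds alone.

Working notes on the series.

Among the measured compounds shown here, compound 1, `Cc1ccccc1-n1nncc1CN1C(=O)C2(C(C#N)=C(N)Oc3c(N)cc4nc5ccccc5nc4c32)c2ccccc21`, is the first member. In a functional assay on MCF7 cells (Homo sapiens) for antiproliferative activity, read by MTT assay, with a stated time of 48 h (a lower number here means a stronger inhibitor, a higher number a weaker inhibitor), compound 1 gives only a limit, > 50000 nM. Compound 2, `Cc1ccc(-n2nncc2CN2C(=O)C3(C(C#N)=C(N)Oc4c(N)cc5nc6ccccc6nc5c43)c3ccccc32)cc1C`, carries the 3,4-dimethylphenyl on the aromatic nitrogen. In this assay compound 2 likewise gives only a limit, > 50000 nM. For the measured compounds named here, the one step within the measured pair, a step that the two limits leave unreadable from compound 1 to compound 2, is therefore unreadable, and the limit of > 50000 nM in this assay, at which 2 of the 2 values shown sit, is the sole fact about the series so far: compound 2 stands at the limit, with no number that could serve as a reference.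

Compound 3, `Cc1ccc(C)c(-n2nncc2CN2C(=O)C3(C(C#N)=C(N)Oc4c(N)cc5nc6ccccc6nc5c43)c3ccccc32)c1`, differs from compound 2 by 2,5-dimethylphenyl in place of 3,4-dimethylphenyl on an aromatic nitrogen. Going by the values given here, no measured step bears on a shift of the methyl groups around the phenyl ring, and the only step recorded is unreadable, so no step beyond the scatter can be predicted in this assay in either direction. On this basis compound 3 is expected to sit near the limit, at an estimated 60000 nM, between 20000 nM and 200000 nM, which corresponds to an expected step that the limit leaves unreadable from compound 2 to compound 3.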

Compound 3, half-maximal inhibitory concentration: > 50000 nM
Compound 3: only a limit was reported; the forecaster's own chance of this, stated with the estimate: 80%; the middle value does not contradict the limit.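

No new step can be read, as compound 1, compound 2 and compound 3 each give only a limit, not a number, in this assay: the limit of > 50000 nM in this assay, at which 3 of the 3 values shown sit.

The compounds shown leave open whether any aryl group on the aromatic nitrogen would give a readable value in this assay.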